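Ester alkyl swap and microsomal stability of compound 4

The source may report more compounds than this note shows. Statements on the series, on what has been measured and on what is new or still open speak of the compounds shown alone.

Compound 3 `CCCCc1nc(C)c(CC(=O)OC(C)C)c(=O)n1Cc1ccc(-c2ccccc2-c2noc(=O)[nH]2)cc1` gives 17.5% in an ADME assay on microsomes from liver (Homo sapiens) for metabolic stability, with a stated time of 30 min; on this read-out higher numbers stand for a more stable compound and lower numbers for a less stable compound. Compound 2 `CCCCc1nc(C(C)C)c(CC(=O)OC2CCCCC2)c(=O)n1Cc1ccc(-c2ccccc2-c2noc(=O)[nH]2)cc1` gives 13.3%, and compound 1 `CCCCc1nc(C(C)C)c(CC(=O)OCC(C)C)c(=O)n1Cc1ccc(-c2ccccc2-c2noc(=O)[nH]2)cc1` gives 8.8%; compound 3 thus holds the highest of the three numbers, yet its gaps to compound 2 and to compound 1 both fall within the scatter. Compound 4 `CCCCc1nc(C)c(CC(=O)OCC(C)C)c(=O)n1Cc1ccc(-c2ccccc2-c2noc(=O)[nH]2)cc1` differs from compound 3 by isobutyl in place of isopropyl on an oxygen next to a carbonyl group. Within the data shown here, the one measured step that bears on this change is a swap of the same kind on the oxygen next to the carbonyl group, a number 4.5 percentage points higher from compound 1 to compound 2 (within the scatter), which moved nothing beyond the scatter. Compound 4 is therefore expected to stay within the scatter of compound 3, with an expected step of a number 4.5 percentage points lower from compound 3 to compound 4 (within the scatter). Compound 4 is estimated at 13%, in a range from 6% to 22%.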

Compound 4, percent of the compound remaining: 2.4%
Beside the measured number, compound 4's estimate is 10.6 percentage points above it; measured number below the stated range.
By their numbers in this assay, from the lowest: compounds 4, 1, 2 and 3 (each within the scatter of the next, the first and the last beyond it).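

In this assay the alkyl group on this oxygen can shift the read-out beyond the scatter: isobutyl in place of isopropyl gives a number 15.1 percentage points lower from compound 3 to compound 4 (beyond the scatter), unlike the earlier swap at this place. With isobutyl held fixed, methyl in place of isopropyl on an aromatic carbon gives only a number 6.4 percentage points lower from compound 1 to compound 4 (within the scatter), which stays within the scatter. Nothing available here accounts for the larger step. As far as these compounds go, whether the same swap holds with isopropyl on that aromatic carbon remains open. So does how a straight butyl chain or an amide in place of the ester would read.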